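This account rests on a few compounds, and the source may have more. Where it says the series, first, only, none or still open, it means among the compounds named here.

Of the compounds shown here, three built on one shared core have been tested in a functional assay on A549 cells (Homo sapiens) for cytotoxicity, read by MTT assay, with a stated time of 72 h; on this read-out higher numbers stand for weaker inhibition and lower numbers for stronger inhibition. Compound 1 `O=C(Nc1ccc(Oc2ccnc3[nH]ccc23)cc1)c1nccc(-c2cccc(Cl)c2)n1` gives 4120 nM in this assay. Compound 2 `COc1ccc(-c2ccnc(C(=O)Nc3ccc(Oc4ccnc5[nH]ccc45)cc3)n2)cc1` carries a 4-methoxyphenyl group in place of the 3-chlorophenyl group and gives 13300 nM in this assay; that exchange is a 3.2-fold higher number from compound 1 to compound 2 (0.51 log units; beyond the scatter). Compound 3 `COc1ccc(-c2cc(C(=O)Nc3ccc(Oc4ccnc5[nH]ccc45)cc3)ncn2)cc1` keeps the 4-methoxyphenyl group on a differently arranged core and gives 4410 nM in this assay. Among the three numbers compound 3 stands second highest: its nearest neighbour is compound 1, within the scatter, and its furthest is compound 2, whose higher number lies beyond the scatter.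

Compound 4 `O=C(Nc1ccc(Oc2ccnc3[nH]ccc23)cc1)c1cc(-c2ccccc2)ncn1` differs from compound 3 by hydrogen in place of methoxy on an aromatic carbon, on an aromatic carbon of a six-membered aromatic ring of carbon only, para to a large group. Among the compounds with values here, no measured step removes a methoxy group alone; the single measured step exchanges whole aryl groups and so does not speak directly to this removal. From compound 3 the expected step in this assay is a 1.1-fold lower number from compound 3 to compound 4 (0.04 log units; within the scatter), a change not beyond the scatter in either direction. Compound 4 is therefore estimated to give about 4000 nM, with a likely range from 1500 nM to 11000 nM.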

Compound 4, half-maximal inhibitory concentration: 140 nM
The estimate for compound 4 lay 29-fold (1.46 log units) above the measured number; the whole stated range lies above it.
By their numbers in this assay, from the lowest: compound 4; then compounds 1 and 3 (each within the scatter of the next); then compound 2.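

In this assay, within the data shown here, the methoxy group para to a large group carries far more weight than the earlier compounds could reveal: replacing it with hydrogen gives a 32-fold lower number from compound 3 to compound 4 (1.50 log units; beyond the scatter). Among these compounds, the only earlier step, on a differently arranged core, exchanged whole aryl groups and gave a 3.2-fold higher number from compound 1 to compound 2 (0.51 log units; beyond the scatter), so it could not isolate what methoxy does on its own. No measurement shown here gives a reason for the size of the new step.

Going by these compounds, it remains open whether other groups at this place, such as a methyl, a fluorine or an amine, would keep the number as low as hydrogen does or raise it as methoxy does. On these data alone, it is also open whether a plain phenyl group would bring a similar drop on the core of compound 2.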